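Hydrogen for Hydroxy on a Saturated Ring Carbon

The compounds below may be only part of what the source reports. "The series", "measured", "known", "first", "only" and "open" are said of these compounds alone.

Measured compounds:
compound 1 `C=C1CC[C@H]2C(C)(C)CCC[C@]2(C)[C@H]1C/C=C1/CCOC1=O`: 6.7 ug/mL
compound 2 `C=C1[C@H](O)C[C@H]2C(C)(C)CCC[C@]2(C)[C@H]1/C=C/c1ccoc1`: 10.3 ug/mL
compound 3 `CC(=O)O[C@]1(C)CC[C@H]2C(C)(C)CCC[C@]2(C)[C@H]1CC=O`: 6.9 ug/mL

In a functional assay on P388 cells (Mus musculus) for cytotoxicity (on this read-out higher numbers stand for weaker inhibition and lower numbers for stronger inhibition), the three measured compounds sit close together. Compound 2 gives the highest of the three numbers, yet its gaps to compound 3 and to compound 1 both lie within the scatter of repeated measurements, so no order among them can be read. Compound 4 `C=C1CC[C@H]2C(C)(C)CCC[C@]2(C)[C@H]1/C=C/c1ccoc1` differs from compound 2 in one place: hydrogen in place of hydroxy on a saturated ring carbon. Among the compounds with values here, no measured pair shows this change, so its effect cannot be read from the measured compounds. With all three measured values close together, the step from compound 2 to compound 4 is expected to be small, a 1.3-fold lower number from compound 2 to compound 4 (0.11 log units; within the scatter), with nothing beyond the scatter. Compound 4 is therefore estimated at 8 ug/mL, within a range from 3 ug/mL to 20 ug/mL.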

Compound 4, half-maximal inhibitory concentration: 10 ug/mL
For compound 4 the middle estimate is 1.3-fold (0.10 log units) below the measured one; low and high end bracket the measured number.
By their numbers in this assay, from the lowest: compounds 1, 3, 4 and 2 (each within the scatter of the next).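

In this assay, within the data shown here, hydrogen in place of hydroxy on the saturated ring carbon gives a 1.0-fold lower number from compound 2 to compound 4 (0.01 log units; within the scatter), the only step in this set that can be read at a single place. On this core, then, losing the hydroxy leaves the number unchanged within the scatter. No measurement at hand offers an explanation for this.

The compounds shown leave open whether an amine or a methoxy group on this ring carbon would move the number beyond the scatter. They also leave open whether the same change would behave alike on the cores of compound 1 and compound 3.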